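Urea-linked quinazolinones: shifting the aryl substituent

The source may report more compounds than this note shows. Statements on the series, on what has been measured and on what is new or still open speak of the compounds shown alone.

Compounds measured so far:
compound 1, `CCc1ccc(NC(=O)Nn2c(-c3ccccc3)nc3ccccc3c2=O)cc1`: 61%
compound 2, `CCc1ccc(NC(=O)Nn2c(CC)nc3ccccc3c2=O)cc1`: 58%
compound 3, `CCc1nc2ccccc2c(=O)n1NC(=O)Nc1ccc(Br)cc1`: 54%

In a functional assay on the whole organism (strain albino) with Mus musculus as the target, at a dose of 100 mg/kg by the intraperitoneal route (on this read-out higher numbers stand for more inhibition at the one dose given (going by the name of the read-out) and lower numbers for less inhibition), compound 1 gives the highest of the three numbers, yet its gaps to compound 2 and compound 3 both lie within the scatter, so no order among them can be claimed. Compound 4, `Cc1ccccc1NC(=O)Nn1c(-c2ccccc2)nc2ccccc2c1=O`, differs from compound 1 by 2-methylphenyl in place of 4-ethylphenyl on an amide-type nitrogen. The nearest measured step is a number 4 percentage points lower from compound 2 to compound 3 (within the scatter), which also altered the group on the aryl ring of the urea; the other step, a number 3 percentage points lower from compound 1 to compound 2 (within the scatter), touched the shared core instead. Both are within the scatter. Compound 4 is therefore expected to show a number 6 percentage points lower from compound 1 to compound 4 (within the scatter), with an estimate of 55% and a range from 40% to 70%.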

Compound 4, a percentage reported as inhibition, in the whole organism at one dose (the size of the read-out at that dose, not a potency): 59%
The estimate for compound 4 lay 4 percentage points below the measured number; the range from low to high includes it.
By their numbers in this assay, from the lowest: compounds 3, 2, 4 and 1 (each within the scatter of the next).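

In this assay, putting 2-methylphenyl in place of 4-ethylphenyl on the amide-type nitrogen gives a number 2 percentage points lower from compound 1 to compound 4 (within the scatter), so this read-out does not separate these two aryl groups when the rest of compound 1 is kept. Unlike the earlier bromo for ethyl step, this change replaces the whole aryl group, with one carbon fewer, and still produces no readable difference. No measurement at hand offers an explanation for this result.

Going by these compounds, whether an amine or a carboxylic acid on this aryl ring would move the number beyond the scatter remains open. With a single dose, the compounds also leave open how their potencies compare.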